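The compounds below may be only part of what the source reports. "The series", "measured", "known", "first", "only" and "open" are said of these compounds alone.

Compound 1 `O=S(=O)(Nc1ccc(-c2nc3ccccc3o2)cc1)c1cccc(F)c1` is a sulfonamide that links a fluorinated phenyl ring to a shared core. In an assay on cells for inhibition of HSP60/HSP10 (Homo sapiens), with a stated time of 60 min (on this read-out higher numbers stand for weaker inhibition and lower numbers for stronger inhibition), compound 1 gives 71000 nM. Of the two plain numbers shown, this is the higher one. Compound 2 `O=S(=O)(Nc1ccc(-c2nc3ccccc3o2)cc1)c1ccc(Cl)c(C(F)(F)F)c1`, which carries a chloro and a trifluoromethyl group on its sulfonyl-bearing ring instead of the single fluoro, gives 12000 nM in this assay, a lower number than compound 1, and the gap between them lies beyond the usual scatter. Compound 3 `O=S(=O)(Nc1ccc2oc(-c3ccccc3)nc2c1)c1cccc(F)c1`, in which the sulfonamide sits on the other end of the core, reaches only the limit of this assay, reported as > 100000 nM; this is a limit and not a measured number (the limit of > 100000 nM in this assay, at which 1 of the 3 values shown sits).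

Compound 4 `O=S(=O)(Nc1ccc(-c2nc3ccccc3o2)cc1)c1cccc(O)c1` is yet to be measured. It differs from compound 1 by hydroxy in place of fluoro on an aromatic carbon. Within the data shown here, no measured pair shows this change, so the expected step from compound 1 to compound 4 is uncertain; it is estimated as a 1.1-fold higher number from compound 1 to compound 4 (0.02 log units; within the scatter), a shift small enough to sit within the scatter, in no firm direction. On that basis compound 4 is expected to give about 75000 nM in this assay, most likely between 30000 nM and 200000 nM.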

Compound 4, half-maximal inhibitory concentration: 62000 nM
Compound 4: the middle estimate sits 1.2-fold (0.08 log units) above what was measured, within the range that was stated.
By their numbers in this assay, from the lowest: compound 2; then compounds 4 and 1 (each within the scatter of the next). At a limit, above all of these: compound 3.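

This is the first change shown that touches only one group on the sulfonyl-bearing ring. In this assay, the exchange of 3-fluorophenyl for 3-hydroxyphenyl gives a 1.1-fold lower number from compound 1 to compound 4 (0.06 log units; within the scatter). So at this place, meta to a large group, a hydroxy with its hydrogen-bond donor and acceptor reads the same as a fluoro, which has neither, within the scatter. Both compounds also sit fairly close to the top of the measurable range, as compound 3 shows: the limit of > 100000 nM in this assay, at which 1 of the 4 values shown sits.

The compounds shown leave open whether an amine, a methoxy or a carboxylic acid at this same place would move the number beyond the scatter. They also leave open whether a hydroxy would read the same alongside the other substituents of compound 2.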